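This account rests on a few compounds, and the source may have more. Where it says the series, first, only, none or still open, it means among the compounds named here.

Compound 2, `CC(C)C(Cc1nnc[nH]1)c1ccc(-c2ccc3cccc(F)c3c2)[nH]c1=O`, stands at the short end of the numbers seen so far in an ADME assay on microsomes from liver (Mus musculus) for metabolic stability; on this read-out lower numbers stand for a shorter-lived compound and higher numbers for a longer-lived compound. In this assay compound 2 gives only a limit, < 0.0667 h, and not a number, so it sits at the limit of < 0.0667 h in this assay, at which 1 of the 3 values shown sits. Compound 1, `CC(C)C(c1ncco1)c1ccc(-c2ccc3cccc(F)c3c2)[nH]c1=O`, gives 0.08 h in this assay, and compound 3, `CC(C)C(Cc1nnn[nH]1)c1ccc(-c2ccc3cccc(F)c3c2)[nH]c1=O`, gives 0.853 h. Between these the steps differ sharply: an at least 1.1-fold lower number from compound 1 to compound 2 (0.07 log units; that floor lies within the scatter), whereas an at least 12-fold higher number from compound 2 to compound 3 (1.10 log units; beyond the scatter) and an 11-fold higher number from compound 1 to compound 3 (1.03 log units; beyond the scatter).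

Compound 4, `CC(C)NC(=O)CC(c1ccc(-c2ccc3cccc(F)c3c2)[nH]c1=O)C(C)C`, differs from compound 2 in one place: isopropylcarbamoyl in place of 4H-1,2,4-triazol-3-yl on a saturated chain carbon, two bonds along the chain from an aromatic carbon. For the measured compounds named here, no measured step swaps in an isopropylcarbamoyl, so the two steps that change the group at this position, from compound 2 to compound 3 and from compound 1 to compound 2, are the only guide. Those show that this position can move this assay by a large amount in one direction or leave it flat. Compound 4 is therefore expected to give a modest rise, an at least 2.2-fold higher number from compound 2 to compound 4 (0.35 log units; beyond the scatter), with wide uncertainty. The estimate for compound 4 in this assay is 0.15 h, within 0.05 h to 0.5 h.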

Compound 4, half-life: < 0.0667 h
Compound 4 ended at the assay's limit; the forecaster's own chance of this, stated with the estimate: 25%; middle value at least 2.2-fold (0.35 log units) from the limit.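

Compound 4 gives only a limit in this assay, so the open-chain isopropylcarbamoyl group, with no ring, ends at the same limit as the ring-bearing 4H-1,2,4-triazol-3-yl group of compound 2: the limit of < 0.0667 h in this assay, at which 2 of the 4 values shown sit. Swapping the 1H-tetrazol-5-yl group for this amide costs a large step (an at least 12-fold lower number from compound 3 to compound 4 (1.10 log units; beyond the scatter)), which shows that the high number of compound 3 does not carry over to an unrelated group at this place, while the step to the amide from the oxazole compound stays within the scatter (an at least 1.1-fold lower number from compound 1 to compound 4 (0.07 log units; that floor lies within the scatter)). The step between compound 2 and compound 4 cannot be read, as both values are limits.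

Going by these compounds, it remains open whether a carboxylic acid on this saturated chain carbon would match compound 3 or fall to the limit. A smaller N-methyl amide leaves the same question for the isopropyl part of compound 4.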